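The source may hold more compounds than are shown below. What is called first, only, known or untested is meant among the compounds shown, and "the series" means these compounds.

Working notes on the series.

Compound 1 `CC(O)(CSc1ccccc1C(F)(F)F)C(=O)Nc1cc(C(F)(F)F)cc(C(F)(F)F)c1` gives 8660 nM in a functional assay on DU-145 cells (Homo sapiens) for antiproliferative activity, read by fluorescence and propidium iodide staining, with a stated time of 96 h; a higher number here means a weaker inhibitor, a lower number a stronger inhibitor. Compound 2 `CC(O)(CSc1cccc(OC(F)(F)F)c1)C(=O)Nc1cc(C(F)(F)F)cc(C(F)(F)F)c1` differs from compound 1 by 3-(trifluoromethoxy)phenyl in place of 2-(trifluoromethyl)phenyl on a sulfur; in this assay compound 2 gives 9610 nM, a step of a 1.1-fold higher number from compound 1 to compound 2 (0.05 log units; within the scatter). Compound 3 `CC(O)(CS(=O)(=O)c1ccccc1C(F)(F)F)C(=O)Nc1cc(C(F)(F)F)cc(C(F)(F)F)c1` is a sulfone relative; the difference between the core of compound 3 and the core of compound 1 is not broken down here. In this assay compound 3 gives 11000 nM, which lies within the scatter of compound 1 and compound 2.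

Compound 4 `CC(O)(CS(=O)(=O)c1cccc(OC(F)(F)F)c1)C(=O)Nc1cc(C(F)(F)F)cc(C(F)(F)F)c1` has not been measured. It differs from compound 3 by 3-(trifluoromethoxy)phenyl in place of 2-(trifluoromethyl)phenyl on a sulfonyl sulfur. This is the same kind of change as from compound 1 to compound 2, though the place differs: there the group sits on a sulfur, here on a sulfonyl sulfur whose other neighbour is a saturated chain carbon. In this assay a step of a 1.1-fold higher number from compound 3 to compound 4 (0.04 log units; within the scatter) is expected, resting on the step of a 1.1-fold higher number from compound 1 to compound 2 (0.05 log units; within the scatter), because compound 3 stands at 11000 nM. Compound 4 is estimated at 12000 nM, with a range from 6000 nM to 25000 nM.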

Compound 4, half-maximal inhibitory concentration: 14100 nM
Beside the measured number, compound 4's estimate is 1.2-fold (0.07 log units) below it; the measured number falls inside the stated range.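

In this assay the swap of 2-(trifluoromethyl)phenyl for 3-(trifluoromethoxy)phenyl on the sulfonyl sulfur gives a 1.3-fold higher number from compound 3 to compound 4 (0.11 log units; within the scatter). Set beside the same swap on the sulfur of the other core, the two steps do not differ: the same change on two cores in this assay, a 1.1-fold higher number (0.05 log units; within the scatter) from compound 1 to compound 2 and a 1.3-fold higher number (0.11 log units; within the scatter) from compound 3 to compound 4, 1.2-fold (0.06 log units) apart, within the scatter of two such steps. This shows that on these two cores the change behaves alike and leaves the number within the scatter, but with both steps so small it does not show that a larger effect would carry over, nor that the agreement extends to any other core.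

Open, on these data alone, is whether an amine, a carboxylic acid or a longer chain in place of these aryl groups would move the number beyond the scatter.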